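The compounds below may be only part of what the source reports. "The series", "measured", "known", "first", "only" and "open" are said of these compounds alone.

Measured set:
compound 1 `O=C(CCc1cccc2c1B(O)OC2)NCc1ccccc1` — > 100000 nM in a functional assay on SK-OV-3 cells (Homo sapiens) for antiproliferative activity, read by MTT assay, with a stated time of 72 h (a lower number here means a stronger inhibitor, a higher number a weaker inhibitor), a limit of the assay
compound 2 `O=C(CCc1cccc2c1B(O)OC2)Nc1ccc(F)cc1` — 720 nM
compound 3 `O=C(CCc1cccc2c1B(O)OC2)Nc1cccc(I)c1` — 630 nM

Compound 1 gives no number in this assay, only the limit (the limit of > 100000 nM in this assay, at which 1 of the 3 values shown sits). The two aryl amides are far stronger: an at least 130-fold lower number from compound 1 to compound 2 (2.14 log units; beyond the scatter) and an at least 150-fold lower number from compound 1 to compound 3 (2.20 log units; beyond the scatter). Compound 3 holds the lowest of the two numbers, but the gap to compound 2 is small, a 1.1-fold lower number from compound 2 to compound 3 (0.06 log units; within the scatter), so the two cannot be ordered.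

Compound 4 `N#Cc1ccc(-c2cccc(NC(=O)CCc3cccc4c3B(O)OC4)c2)cc1` is next. The change is 4-cyanophenyl in place of iodo on an aromatic carbon. Within the data shown here, the steps that bear on it are the two from compound 1, which show that an aryl on the amide nitrogen is what sets the number, and the step from compound 2 to compound 3, which shows that swapping one aromatic substituent for another moved the number no further than the scatter. Among the measured compounds shown here, a 4-cyanophenyl in place of iodo is a larger change than any measured here, with no direct precedent. The step of a 1.3-fold lower number from compound 3 to compound 4 (0.10 log units; within the scatter) is therefore expected to be small, likely within the scatter. Compound 4 is estimated at 500 nM, within 150 nM to 2000 nM.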

Compound 4, half-maximal inhibitory concentration: 340 nM
Beside the measured number, compound 4's estimate is 1.5-fold (0.17 log units) above it; the range from low to high includes it.
By their numbers in this assay, from the lowest: compounds 4, 3 and 2 (each within the scatter of the next, the first and the last beyond it). At a limit, above all of these: compound 1.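

On an aromatic carbon, meta to a large group, a single iodine atom gives way to a 4-cyanophenyl of 8 heavy atoms, with a second six-membered aromatic ring and a nitrile, and this assay shows a 1.9-fold lower number from compound 3 to compound 4 (0.27 log units; within the scatter). Among these compounds, the earlier aryl amides carried only one halogen atom on the ring, so this is the first sign that a much larger group can sit at this position with the number staying within the scatter of the iodo compound. Nothing measured in this set bears on why the number holds across this change.

Still open, as far as these compounds go, is whether an amine or a carboxylic acid on this same aromatic carbon would stay in this range, and whether an unsubstituted phenyl would read like the 4-cyanophenyl. Also open, from the compounds shown here alone, is how a longer chain on the amide carbonyl would read.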